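The source may hold more compounds than are shown below. What is called first, only, known or untested is meant among the compounds shown, and "the series" means these compounds.

Measured compounds:
- compound 1 `COc1cc(Cl)cc(-c2nn(-c3cccc(NC(=O)Nc4ccc(Cl)c(Cl)c4)c3)cc2-c2ccncc2)c1`: 82%
- compound 2 `COc1cc(Cl)cc(-c2nn(-c3cccc(NC(=O)Nc4cccc(C(F)(F)F)c4)c3)cc2-c2ccncc2)c1`: 43%

In a functional assay on A549 cells (Homo sapiens) for inhibition, read by sulforhodamine B assay, with a stated time of 48 h, tested at 1 uM (a lower number here means a stronger effect, a higher number a weaker effect of the compound at the concentration tested), compound 1 gives 82%, and compound 2 gives 43%, which is the lower, that is the stronger, of the two numbers. Among the compounds with values here, the one measured step, a number 39 percentage points lower from compound 1 to compound 2 (beyond the scatter), concerns the aryl group on the amide-type nitrogen of the urea and is large.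

Compound 3 `COc1cc(Cl)cc(-c2nn(-c3cccc(NC(=O)c4cccc(C(F)(F)F)c4)c3)cc2-c2ccncc2)c1` differs from compound 2 in another place: 3-(trifluoromethyl)phenyl in place of (3-(trifluoromethyl)phenyl)amino on a carbonyl carbon. In effect the urea of compound 2 becomes an amide, with one hydrogen-bond donor fewer. Within the data shown here, no measured step bears on this change; the step from compound 1 to compound 2 swaps one aryl group for another on the same urea and says nothing about losing the amino link itself. The expectation for compound 3 must therefore rest on compound 2 alone and carries a wide range. The estimate for compound 3 is a somewhat weaker effect, a step of a number 19 percentage points higher from compound 2 to compound 3 (beyond the scatter) relative to compound 2, giving an expected value of 62% with a range from 30% to 95% in this assay.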

Compound 3, a percentage reported as activity, at one concentration (the size of the read-out at that concentration, not a potency): 75%
Beside the measured number, compound 3's estimate is 13 percentage points below it; low and high end bracket the measured number.
By their numbers in this assay, from the lowest: compound 2; then compounds 3 and 1 (each within the scatter of the next).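

In this assay the swap on the carbonyl carbon, where 3-(trifluoromethyl)phenyl replaces (3-(trifluoromethyl)phenyl)amino and the urea becomes an amide, gives a number 32 percentage points higher from compound 2 to compound 3 (beyond the scatter) and is a large step. Within the data shown here, the earlier step showed only that the aryl group on the urea matters; this one shows that the amino link matters too, since the same 3-(trifluoromethyl)phenyl group gives a clearly weaker effect at the tested concentration once that link is gone. With a number 7 percentage points lower from compound 1 to compound 3 (within the scatter) the amide and the 3,4-dichlorophenyl urea cannot be told apart, so among these three structures only compound 2, the urea carrying 3-(trifluoromethyl)phenyl, stands clearly apart from the others.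

Still open, from the compounds shown here alone, is whether another link on the carbonyl carbon, such as the oxygen of a carbamate or a methylene group in place of the amino nitrogen, would keep the stronger effect or lose it as the amide does. Nothing available explains why removing the amino link has so large an effect in these cells.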